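The compounds below may be only part of what the source reports. "The series", "measured", "known", "first", "only" and "open" are said of these compounds alone.

Of the compounds shown here, three have been tested in a functional assay on BV-2 cells (Mus musculus), with stated times of 2 h and 24 h, tested at 1 uM; on this read-out higher numbers stand for a weaker effect at the one concentration tested and lower numbers for a stronger effect. Compound 1 `COc1cc([C@@H]2O[C@@H](CC(=O)CCc3ccc(O)cc3)[C@@H]3[C@H]2[C@H](CC(=O)CCc2ccc(O)cc2)O[C@H]3c2ccc(O)c(OC)c2)ccc1O` gives 101% in this assay, compound 2 `COc1cc([C@@H]2O[C@@H](CC(=O)CCc3ccc(O)cc3)[C@@H]3[C@H]2[C@H](CC(=O)CCc2ccc(O)cc2)O[C@H]3c2ccc(O)cc2)ccc1O` gives 99.6%, and compound 3 `Oc1ccc(CC[C@@H](O)C[C@H](O)CCc2ccc(O)cc2)cc1` gives 102%; all three numbers lie within the usual scatter of one another. Compound 2 and compound 1 differ by methoxy in place of hydrogen on an aromatic carbon, and that change made a step of a number 1.4 percentage points higher from compound 2 to compound 1 (within the scatter). Compound 4 `COc1cc(CC[C@@H](O)C[C@H](O)CCc2ccc(O)cc2)ccc1O` is not yet measured; it differs from compound 3 by methoxy in place of hydrogen on an aromatic carbon, the same change at the same kind of place. The difference between the cores of compound 3 and compound 2 is not broken down here. Because the change gave a number 1.4 percentage points higher from compound 2 to compound 1 (within the scatter), the expected step here is a number 1 percentage points higher from compound 3 to compound 4 (within the scatter), a shift within the scatter. Compound 4 is therefore estimated at 103%, lying between 95% and 110%.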

Compound 4, a percentage reported as activity, at one concentration (the size of the read-out at that concentration, not a potency): 99.4%
Compound 4: middle estimate off by 3.6 percentage points, on the high side; low and high end bracket the measured number.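

In this assay, methoxy in place of hydrogen on an aromatic carbon gave a number 2.6 percentage points lower from compound 3 to compound 4 (within the scatter). Set side by side, the two steps cannot be told apart: the same change on two cores in this assay, a number 1.4 percentage points higher (within the scatter) from compound 2 to compound 1 and a number 2.6 percentage points lower (within the scatter) from compound 3 to compound 4, 4 percentage points apart, within the scatter of two such steps So on both cores this change left the read-out within the scatter at the one concentration tested, but that does not show that the two cores would respond alike to a change with a clear effect.

On these data alone, whether an amine or a carboxylic acid on the same aromatic carbon would give a step beyond the scatter stays open. So does whether the methoxy change would show any effect at another concentration.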